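A few compounds are considered here, and "the series" means these few. Any claim that something is new, unique, unknown or untested is made for them only; others in the source may bear on it.

Within → In. Here is the whole part again:

THE PART
In a functional assay on Ramos cells (Homo sapiens) for antiproliferative activity, read by CCK-8 assay, with a stated time of 72 h, tested at 40 uM (on this read-out lower numbers stand for less inhibition and higher numbers for more inhibition at the one concentration tested (going by the name of the read-out)), compound 1 `CCOC(=O)c1sc(-c2cccc(NC(=O)c3ccc(C(C)(C)C)cc3)c2)nc1Nc1ccc(N2CCN(C)CC2)cc1` gives 21.2%, compound 2 `CCOC(=O)c1sc(-c2cccc(NC(=O)c3cccc(F)c3)c2)nc1Nc1ccc(N2CCN(C)CC2)cc1` gives 85.2%, and compound 3 `CCOC(=O)c1sc(-c2cccc(NC(=O)c3ccc(C(F)(F)F)cn3)c2)nc1Nc1ccc(N2CCN(C)CC2)cc1` gives 19%. Compound 2 stands highest of the three numbers, reached by a number 64 percentage points higher from compound 1 to compound 2 (beyond the scatter) and left again by a number 66.2 percentage points lower from compound 2 to compound 3 (beyond the scatter), whereas a number 2.2 percentage points lower from compound 1 to compound 3 (within the scatter). Compound 4 `CN1CCN(c2ccc(Nc3nc(-c4cccc(NC(=O)c5cccc(F)c5)c4)sc3C(N)=O)cc2)CC1` differs from compound 2 by amino in place of ethoxy on a carbonyl carbon. Among the measured compounds shown here, both large measured steps exchange the aryl group on a different carbonyl carbon; none alters the ethoxycarbonyl, so no measured step bears directly on this change, and the expectation rests on compound 2 alone. For compound 4 the step expected from compound 2 is a number 13.2 percentage points lower from compound 2 to compound 4 (beyond the scatter), judged within the scatter but with wide uncertainty. Compound 4 is therefore estimated at 72%, between 35% and 95%.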

Compound 4, a percentage reported as inhibition, at one concentration (the size of the read-out at that concentration, not a potency): 16.2%
Compound 4: middle estimate off by 55.8 percentage points, on the high side; the measured number lies below the stated range.
By their numbers in this assay, from the lowest: compounds 4, 3 and 1 (each within the scatter of the next); then compound 2.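

Ethoxycarbonyl is not a silent site in this assay: carbamoyl in its place gives a number 69 percentage points lower from compound 2 to compound 4 (beyond the scatter), so a large step is no longer confined to exchange of the aryl group on the other carbonyl carbon. The 3-fluorophenyl amide alone does not carry the inhibition, since compound 4 keeps it and gives 16.2%. Nothing available explains this step.

Open, from the compounds shown here alone, is how a carboxylic acid or a methyl ester on this carbonyl carbon would read. Also open, going by these compounds, is whether the same exchange gives a similar step with the other aryl groups.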